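This account rests on a few compounds, and the source may have more. Where it says the series, first, only, none or still open, it means among the compounds named here.

Compound 3 `Cc1ccc(S(=O)(=O)N2CCN(c3ccc(C(=O)/C=C/c4ccccc4)cc3)CC2)cc1` carries a (4-methylphenyl)sulfonyl group on the amine nitrogen in a ring of the shared core. In a functional assay on the whole organism (strain Kunming) for inhibition, with Mus musculus as the target, with a stated time of 1 h, at a dose of 40 mg/kg by the oral route (a lower number here means less inhibition, a higher number more inhibition at the dose given (going by the name of the read-out)), compound 3 gives 30.8%, the highest of the three numbers in hand. Compound 1 `COc1cccc(N2CCN(c3ccc(C(=O)/C=C/c4ccccc4)cc3)CC2)c1` gives 16% in this assay, and compound 2 `Cc1ccc(N2CCN(c3ccc(C(=O)/C=C/c4ccccc4)cc3)CC2)cc1` gives 2.85%. The steps among these three are a number 14.8 percentage points higher from compound 1 to compound 3 (beyond the scatter), a number 28 percentage points higher from compound 2 to compound 3 (beyond the scatter) and a number 13.2 percentage points lower from compound 1 to compound 2 (beyond the scatter); each of them swaps the whole group on the amine nitrogen in a ring, and all three lie beyond the scatter.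

Compound 4 `CCCCc1ccc(S(=O)(=O)N2CCN(c3ccc(C(=O)/C=C/c4ccccc4)cc3)CC2)cc1` differs from compound 3 by propyl in place of hydrogen on a saturated chain carbon bound to an aromatic carbon, read one bond further out as methyl to butyl, or 4-methylphenyl to 4-butylphenyl, with the rest of the shared core unchanged. Among the measured compounds shown here, none of the measured steps bears on this kind of change: every pair in hand exchanges the entire substituent on the amine nitrogen in a ring, and no pair differs only at a saturated chain carbon bound to an aromatic carbon. For the measured compounds named here, with no comparable step to draw on, the working expectation is a step of a number 0.8 percentage points lower from compound 3 to compound 4 (within the scatter) in this assay, that is, no change beyond the scatter in either direction. Compound 4 is therefore estimated at 30% in this assay, with a range from 15% to 45%.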

Compound 4, a percentage reported as inhibition, in the whole organism at one dose (the size of the read-out at that dose, not a potency): 24%
For compound 4 the middle estimate is 6 percentage points above the measured one; measured number inside the range.
By their numbers in this assay, from the lowest: compound 2; then compounds 1, 4 and 3 (each within the scatter of the next, the first and the last beyond it).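

Among the compounds shown here, the series now holds a first pair that differs only on a saturated chain carbon bound to an aromatic carbon, and in this assay propyl in place of hydrogen at this place gives a number 6.8 percentage points lower from compound 3 to compound 4 (within the scatter), so the change from 4-methylphenyl to 4-butylphenyl leaves no shift beyond the scatter. The earlier steps shown here all exchanged the whole group on the amine nitrogen in a ring and all lay beyond the scatter, whereas this pair shows that, with the sulfonyl group kept, this one extension of the chain can be made without a clear change in the read-out. No measurement is at hand that would explain this result.

Still open, going by these compounds, is whether a chain longer than butyl, or an amine or a carboxylic acid at this place, would also stay within the scatter of compound 3. Also open, on these data alone, is whether the same change from methyl to butyl would read alike where the 4-methylphenyl group sits directly on the amine nitrogen in a ring, as in compound 2.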